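The compounds below may be only part of what the source reports. "The series", "measured", "known", "first", "only" and "open" are said of these compounds alone.

Compound 1 `COc1ccc(C(=O)Nc2ccccc2Br)cc1OC1CCCC1` gives 130 nM in an assay on isolated protein for inhibition of phosphodiesterase 4A (Sus scrofa); a lower number here means a stronger inhibitor, a higher number a weaker inhibitor. Compound 2 `COc1ccc(C(=O)Nc2ccccc2C(F)(F)F)cc1OC1CCCC1` gives 3100 nM. Compound 3 `COc1ccc(C(=O)Nc2ccccc2C(=O)c2ccccc2)cc1OC1CCCC1` gives 1700 nM.

On these numbers compound 3 stands second highest of the three: its gap to compound 2 is within the scatter (a 1.8-fold lower number from compound 2 to compound 3 (0.26 log units; within the scatter)), whereas the step of a 13-fold higher number from compound 1 to compound 3 (1.12 log units; beyond the scatter) is beyond it. Compound 4 `COc1ccc(C(=O)Nc2ccccc2O)cc1OC1CCCC1` differs from compound 3 by hydroxy in place of benzoyl on an aromatic carbon. Within the data shown here, no measured step carries a hydroxy, so the bearing is indirect: a 13-fold higher number from compound 1 to compound 3 (1.12 log units; beyond the scatter) and a 1.8-fold lower number from compound 2 to compound 3 (0.26 log units; within the scatter) show that the two large groups at this carbon go with the higher numbers, while the smaller bromo of compound 1 goes with the lowest number, 130 nM. Compound 4 is therefore expected to give a lower number than compound 3, by about a 4.9-fold lower number from compound 3 to compound 4 (0.69 log units; beyond the scatter). The estimate for compound 4 in this assay is 350 nM, within 70 nM to 1700 nM.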

Compound 4, half-maximal inhibitory concentration: 1300 nM
The estimate for compound 4 lay 3.7-fold (0.57 log units) below the measured number; the measured number falls inside the stated range.
By their numbers in this assay, from the lowest: compound 1; then compounds 4, 3 and 2 (each within the scatter of the next, the first and the last beyond it).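

Removing nearly all of the benzoyl bulk at this carbon does not restore the low number of compound 1: with hydroxy, 1 heavy atom against 8, the result is a 1.3-fold lower number from compound 3 to compound 4 (0.12 log units; within the scatter) in this assay. Hydroxy still separates modestly from trifluoromethyl (a 2.4-fold lower number from compound 2 to compound 4 (0.38 log units; beyond the scatter)), but it remains well short of bromo (a 10-fold higher number from compound 1 to compound 4 (1.00 log units; beyond the scatter)), so a small group here is not sufficient for the bromo result. Nothing measured on these compounds explains the difference between hydroxy and bromo. Open, going by these compounds, is how chloro, methyl, methoxy or an amine at this carbon would compare with bromo.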